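The compounds below may be only part of what the source reports. "The series", "measured", "known", "first", "only" and "open" are said of these compounds alone.

Measured so far:
compound 1, `COc1ccc(-c2cc(/C=C/C(=O)c3ccc(N)cc3)[nH]n2)cc1`: 97%
compound 2, `COc1cc(-c2cc(/C=C/C(=O)c3ccc(N)cc3)[nH]n2)cc(OC)c1OC`: 88%

Both numbers come from a functional assay on Hs-578T cells (Homo sapiens) for cytotoxicity, read by sulforhodamine B assay, with a stated time of 48 h, tested at 0.1 uM; a higher number here means a weaker effect of the compound at the concentration tested, a lower number a stronger effect. A compound that leaves nearly all the cells alive at this concentration scores high, so both compounds show only a weak effect here. Compound 2 gives 88%. Compound 1 gives 97%. For the measured compounds named here, the two numbers lie within the usual scatter of each other, so nothing separates compound 2 from compound 1 on this evidence; compound 2 stands level with its only neighbour.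

Compound 3, `COc1ccc(-c2cc(/C=C/C(=O)c3ccc(N)cc3)[nH]n2)cc1OC`, has not been measured yet. It differs from compound 2 in one place: hydrogen in place of methoxy on an aromatic carbon. Going by the values given here, no step between measured compounds isolates this change, so there is nothing to lean on except the two numbers. Because compound 2 gives 88% and compound 1 gives 97% while carrying different numbers of methoxy groups, little movement is expected from one methoxy more or less. The step of a number 5 percentage points higher from compound 2 to compound 3 (within the scatter) is expected to be none beyond the scatter. Compound 3 is therefore estimated at 93%, with a range from 82% to 100%.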

Compound 3, a percentage reported as activity, at one concentration (the size of the read-out at that concentration, not a potency): 93%
The estimate for compound 3 equals the measured number at the digits printed; the measured number falls inside the stated range.
By their numbers in this assay, from the lowest: compounds 2, 3 and 1 (each within the scatter of the next).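

Compound 3 links the two earlier compounds through single changes, which they could not do on their own. In this assay the step of a number 5 percentage points higher from compound 2 to compound 3 (within the scatter) comes with hydrogen in place of methoxy on an aromatic carbon, at a place ortho to a methoxy group, and the step of a number 4 percentage points lower from compound 1 to compound 3 (within the scatter) comes with methoxy in place of hydrogen on an aromatic carbon. Since both steps lie within the scatter, neither change separates the compounds at this single tested concentration, and no measurement here offers an explanation for that result.

From the compounds shown here alone, only methoxy and hydrogen have been compared at these places, so it remains open whether a hydroxyl group, a fluorine atom, an amine or a longer chain such as ethoxy would leave the read-out just as unchanged. With every number here at the weak end of the read-out, these compounds also leave open whether a methoxy group matters under conditions where the shared core has a stronger effect on the cells.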